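Swapping a phenyl for 4-chlorobenzyl on the shared core

The compounds below may be only part of what the source reports. "The series", "measured", "known", "first", "only" and "open" are said of these compounds alone.

Compound 1 `O=C(O)c1ccccc1-c1ccc(CCc2ncc(-c3ccccc3)[nH]2)cc1` is the starting point. Within the data shown here, in an in vitro functional assay on cells for agonist activity at Bombesin receptor subtype-3 (Homo sapiens), read by luminescence and calcium flux (a lower number here means that less compound is needed, a higher number that more compound is needed for the effect), compound 1 gives 4950 nM, the highest of the two numbers measured so far. Compound 2 `Cc1ccc(Cc2cnc(CCc3ccc(-c4ccccc4C(=O)O)cc3)[nH]2)cc1` gives 2660 nM, and the step of a 1.9-fold lower number from compound 1 to compound 2 (0.27 log units; within the scatter) shows that the 4-methylbenzyl change stayed within the scatter. Compound 3 `O=C(O)c1ccccc1-c1ccc(CCc2ncc(Cc3ccc(Cl)cc3)[nH]2)cc1` carries a related change: 4-chlorobenzyl in place of phenyl on an aromatic carbon. Among the measured compounds shown here, the one step that bears on it was small, so no more than a modest move, if any, toward a lower number is expected in this assay, as a 1.9-fold lower number from compound 1 to compound 3 (0.28 log units; within the scatter). Compound 3 is therefore estimated at 2600 nM, with a likely range from 1000 nM to 6500 nM.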

Compound 3, half-maximal effective concentration: 2290 nM
Compound 3: middle estimate off by 1.1-fold (0.06 log units), on the high side, within the range that was stated.
By their numbers in this assay, from the lowest: compounds 3, 2 and 1 (each within the scatter of the next, the first and the last beyond it).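

In this assay, 4-chlorobenzyl in place of phenyl on this aromatic carbon gives a 2.2-fold lower number from compound 1 to compound 3 (0.33 log units; beyond the scatter), so a benzyl-type group here now gives a modest step rather than one inside the scatter. Chloro in place of methyl gives a 1.2-fold lower number from compound 2 to compound 3 (0.07 log units; within the scatter), so these two benzyl groups cannot be told apart in this assay. Nothing shown here offers an explanation for these steps. Still open, as far as these compounds go, is whether an amine on that six-membered ring, or a longer chain carrying the ring, would move the number further.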